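Indoline in place of a pyridylmethyl amine on the dithiocarbamate

A few compounds are considered here, and "the series" means these few. Any claim that something is new, unique, unknown or untested is made for them only; others in the source may bear on it.

Compound 1 `CCN(Cc1ccncc1)C(=S)SCc1ccc(C(=O)Nc2ccccc2N)cc1`: 1040 nM
Compound 2 `Nc1ccccc1NC(=O)c1ccc(CSC(=S)N2CCN(c3ccc(F)cc3)CC2)cc1`: "not determined" (no result reported)

In a functional assay on HeLa cells (Homo sapiens) for antiproliferative activity, read by CCK-8 assay, with a stated time of 72 h (a lower number here means a stronger inhibitor, a higher number a weaker inhibitor), compound 1 gives 1040 nM. Among the compounds with values here, that is the only number available, since compound 2 is recorded as "not determined" (no result reported) in this assay, so compound 1 stands alone without a comparison partner. Compound 3 `Nc1ccccc1NC(=O)c1ccc(CSC(=S)N2CCc3ccccc32)cc1` keeps the shared core and the thiocarbonyl carbon of compound 1 and differs only there: 2,3-dihydro-1H-indol-1-yl in place of ethyl((pyridin-4-yl)methyl)amino on a thiocarbonyl carbon. Within the data shown here, no measured pair shows what such an exchange on the thiocarbonyl carbon does, so the expectation rests on compound 1 alone, with the group that enters being of similar size to the one that leaves. The step from compound 1 to compound 3 is therefore expected to be small, a 1.2-fold lower number from compound 1 to compound 3 (0.06 log units; within the scatter), not beyond the scatter in either direction. For compound 3 the estimate in this assay is 900 nM, with a range from 300 nM to 2700 nM.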

Compound 3, half-maximal inhibitory concentration: 3450 nM
The estimate for compound 3 lay 3.8-fold (0.58 log units) below the measured number, and the stated range ends below it.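

In this assay, within the data shown here, the first measured exchange on the thiocarbonyl carbon gives a 3.3-fold higher number from compound 1 to compound 3 (0.52 log units; beyond the scatter) and so shows that this position responds to the group it carries, even when the entering group and the leaving group are of similar size. The step is modest, yet it lies beyond the scatter, and 2,3-dihydro-1H-indol-1-yl gives the weaker result of the two. No measurement on these compounds accounts for the step.

Among these compounds, the single step cannot separate the removal of the pyridin-4-yl ring from the closing of the amine into a ring, as both changes occur together. The compounds shown leave open how a diethylamino group or a morpholin-4-yl group on the thiocarbonyl carbon would compare with ethyl((pyridin-4-yl)methyl)amino.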